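Sulfonamide series: vinyl replaces hydroxy on the sulfonyl aryl

The source may hold more compounds than are shown below. What is called first, only, known or untested is meant among the compounds shown, and "the series" means these compounds.

Compound 1 `O=S(=O)(Nc1ccc(-c2nc3ccccc3o2)cc1)c1ccccc1C(F)(F)F` carries a trifluoromethyl on the aryl bound to the sulfonyl sulfur. In an assay on isolated protein for inhibition of malate dehydrogenase, mitochondrial (Sus scrofa), with stated times of 45 min and 30 min (a higher number here means a weaker inhibitor, a lower number a stronger inhibitor), compound 1 gives > 63000 nM, which is a limit of the assay and not a number. Compound 2 `O=S(=O)(Nc1ccc(-c2nc3ccccc3o2)cc1)c1ccccc1O` differs by hydroxy in place of trifluoromethyl on an aromatic carbon. In this assay compound 2 gives > 63000 nM, again a limit rather than a number. The step that the two limits leave unreadable from compound 1 to compound 2 therefore cannot be read in size or direction; both values sit at the limit of > 63000 nM in this assay, at which 2 of the 2 values shown sit. Where compound 2 stands is thus known only as a limit, with no number to set it against.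

Compound 3 `C=Cc1ccc(S(=O)(=O)Nc2ccc(-c3nc4ccccc4o3)cc2)cc1` is the next member: 4-vinylphenyl in place of 2-hydroxyphenyl on a sulfonyl sulfur. For the measured compounds named here, no measured step bears on this change, since the single step known, trifluoromethyl to hydroxy, is itself unreadable. The expectation for compound 3 rests only on the limit shown for compound 2. The step from compound 2 to compound 3 is expected to be a step that the limit leaves unreadable from compound 2 to compound 3, most likely not readable either. Compound 3 is estimated at 80000 nM, with a range from 20000 nM to 300000 nM, and a further limit rather than a number is the most likely result.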

Compound 3, half-maximal inhibitory concentration: > 63000 nM
Compound 3 ended at the assay's limit; the forecaster's own chance of this, stated with the estimate: 75%; the middle value does not contradict the limit.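

In this assay compound 3 gives > 63000 nM, a limit of the assay and not a number. The change from compound 2 to compound 3 therefore yields no readable step, in size or direction: the limit of > 63000 nM in this assay, at which 3 of the 3 values shown sit. The compounds shown leave open whether any group on the aryl bound to the sulfonyl sulfur gives a readable value in this assay.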